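The source may hold more compounds than are shown below. What is called first, only, known or untested is meant among the compounds shown, and "the series" means these compounds.

Compounds measured in a functional assay, read by spectrophotometry, with a stated time of 2 h, tested at 1 mg/mL; a lower number here means a weaker effect, a higher number a stronger effect of the compound at the concentration tested:
compound 1 `CC(C)[C@@H]1CC[C@@H](C)C[C@@]12N(C)C(=O)[C@@H]1[C@H]3C(=O)N(c4ccccc4)C(=O)[C@H]3ON12` — 29.7%
compound 2 `CC(C)[C@@H]1CC[C@@H](C)C[C@@]12N(C)C(=O)[C@@H]1[C@H]3C(=O)N(c4ccc(Cl)cc4)C(=O)[C@H]3ON12` — 39.9%
compound 3 `COc1ccc(N2C(=O)[C@H]3[C@H](ON4[C@@H]3C(=O)N(C)[C@@]43C[C@H](C)CC[C@H]3C(C)C)C2=O)cc1` — 61%

Compound 3 stands at the top of these three numbers: its step from compound 2 is beyond the scatter, and its step from compound 1 more so. The shared core is unchanged across the set; the three differ only in the group on the aromatic ring attached to the amide-type nitrogen. The steps seen are a number 10.2 percentage points higher from compound 1 to compound 2 (beyond the scatter), a number 31.3 percentage points higher from compound 1 to compound 3 (beyond the scatter) and a number 21.1 percentage points higher from compound 2 to compound 3 (beyond the scatter).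

Compound 4 `Cc1cccc(N2C(=O)[C@H]3[C@H](ON4[C@@H]3C(=O)N(C)[C@@]43C[C@H](C)CC[C@H]3C(C)C)C2=O)c1` has not yet been measured. Its change from compound 3 is 3-methylphenyl in place of 4-methoxyphenyl on an amide-type nitrogen in a ring. The 4-methoxyphenyl group, which gave compound 3 its lead, departs; the 3-methylphenyl that enters carries no hydrogen-bond acceptor, like the phenyl of compound 1 and the 4-chlorophenyl of compound 2. Going by the values given here, no measured step puts a methyl on this ring, so the size of the step can only be inferred from how compound 3 stands against compound 1 and compound 2. A downward step, beyond the scatter, is expected: the estimate for compound 4 in this assay is 42%, within 25% to 62%, an expected step of a number 19 percentage points lower from compound 3 to compound 4 (beyond the scatter).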

Compound 4, a percentage reported as activity, at one concentration (the size of the read-out at that concentration, not a potency): 25.8%
Beside the measured number, compound 4's estimate is 16.2 percentage points above it; measured number inside the range.
By their numbers in this assay, from the lowest: compounds 4 and 1 (each within the scatter of the next); then compound 2; then compound 3.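

In this assay, the 3-methylphenyl on the amide-type nitrogen does not separate from the unsubstituted phenyl, with a number 3.9 percentage points lower from compound 1 to compound 4 (within the scatter), whereas the chloro and methoxy changes each moved the read-out beyond the scatter. Putting 3-methylphenyl in place of the substituted rings gives a number 35.2 percentage points lower from compound 3 to compound 4 (beyond the scatter) and a number 14.1 percentage points lower from compound 2 to compound 4 (beyond the scatter), so among these compounds a group added to this aromatic ring does not by itself raise the read-out: compound 2 and compound 3 rise above the phenyl of compound 1, while compound 4 goes against that pattern. Nothing measured alongside these numbers bears on why the group on this ring changes the read-out so much.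

Methyl, chloro and methoxy each appear at only one place on the ring, so the compounds shown cannot tell the effect of the group from the effect of where it sits. From the compounds shown here alone, whether an amine, a carboxylic acid or a longer alkoxy chain on this ring would hold the read-out of compound 3 also remains open.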